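A second methoxy on the shared core

The compounds below may be only part of what the source reports. "The series", "measured", "known", "first", "only" and "open" are said of these compounds alone.

Compound 2, `COc1ccc(-c2cn(-c3ccc(OC(F)(F)F)cc3)nn2)cc1`, gives 1000 nM in a functional assay on MDA-MB-231 cells (Homo sapiens) for cytotoxicity, read by MTT assay (on this read-out lower numbers stand for stronger inhibition and higher numbers for weaker inhibition), the lowest of the two numbers measured. Compound 1, `COc1cc(-c2cn(-c3ccc(OC(F)(F)F)cc3)nn2)ccc1O`, gives 10000 nM in this assay, a number that stands beyond the scatter above compound 2. Compound 3, `COc1ccc(-c2cn(-c3ccc(OC(F)(F)F)cc3)nn2)cc1OC`, has not been measured; it differs from compound 2 by methoxy in place of hydrogen on an aromatic carbon. Among the compounds with values here, no step between measured compounds is available, so the only guide is the gap between compound 1 and compound 2. A weaker result is expected for compound 3, a step of a 3.0-fold higher number from compound 2 to compound 3 (0.48 log units; beyond the scatter) upward beyond the scatter. Compound 3 is therefore estimated at 3000 nM, within 1000 nM to 15000 nM.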

Compound 3, half-maximal inhibitory concentration: > 1000 nM
Compound 3 gave a limit, no number; the forecaster's own chance of this, stated with the estimate: 15%; the middle value lies beyond the limit too.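

In this assay compound 3 gives > 1000 nM as a limit of the assay, not a number. Methoxy in place of hydrogen at this place, ortho to a methoxy group, brings a number no lower from compound 2 to compound 3 (the limit leaves the size open) and so shows no gain over compound 2. The steps to compound 3 cannot be read in size because its value is a limit: the limit of > 1000 nM in this assay, at which 1 of the 3 values shown sits.

From the compounds shown here alone, whether compound 3 stands close to compound 1 stays open. How an amine or a longer chain such as ethoxy would read at this place also stays open, as neither is among the compounds shown.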